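The source may report more compounds than this note shows. Statements on the series, on what has been measured and on what is new or still open speak of the compounds shown alone.

Among the measured compounds shown here, in an ADME assay on HeLa cells (Homo sapiens) for cytotoxicity, read by crystal violet staining, with a stated time of 72 h (a higher number here means that more compound is tolerated, a lower number that less compound is tolerated), compound 1 `CN(C)C(=O)c1cc(CCCOc2ccc(-c3noc(C(F)(F)F)n3)cc2F)on1` gives 20200 nM and compound 2 `CN(C)C(=O)c1cc(CCCOc2ccc(-c3noc(C(F)(F)F)n3)cc2C(F)(F)F)on1` gives 19200 nM, so compound 2 stands within the scatter of the only other measured compound. Compound 3 `CN(C)C(=O)c1cc(CCCOc2ccc(-c3noc(C(F)(F)F)n3)cc2N)on1` has amino in place of trifluoromethyl on an aromatic carbon, ortho to a large group and meta to a 5-(trifluoromethyl)-1,2,4-oxadiazol-3-yl group: amino in place of trifluoromethyl on an aromatic carbon. A single measured step bears on this place: a 1.1-fold lower number from compound 1 to compound 2 (0.02 log units; within the scatter), trifluoromethyl in place of fluoro, which lies within the scatter. For the measured compounds named here, no measured compound carries amino there, so this one step gives only thin guidance, and the range must stay wide. No step beyond the scatter is expected in this assay. The expected change is a 1.1-fold lower number from compound 2 to compound 3 (0.05 log units; within the scatter). For compound 3 the estimated value is 17000 nM, with an expected range from 8000 nM to 32000 nM.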

Compound 3, half-maximal cytotoxic concentration: 90800 nM
Compound 3: the middle estimate sits 5.3-fold (0.73 log units) below what was measured, outside the stated range (above it).
By their numbers in this assay, from the lowest: compounds 2 and 1 (each within the scatter of the next); then compound 3.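

In this assay, this aromatic carbon, ortho to a large group and meta to a 5-(trifluoromethyl)-1,2,4-oxadiazol-3-yl group, proves responsive to what it carries: amino gives a 4.7-fold higher number from compound 2 to compound 3 (0.67 log units; beyond the scatter) and a 4.5-fold higher number from compound 1 to compound 3 (0.65 log units; beyond the scatter). The earlier change from fluoro to trifluoromethyl, a 1.1-fold lower number from compound 1 to compound 2 (0.02 log units; within the scatter), had shown no such movement, so amino is the first group here to shift the number beyond the scatter, towards more compound being tolerated. Nothing available here accounts for this shift.

The compounds shown leave open whether the rise is particular to amino or would also appear with a hydroxyl, a methoxy or an acetamide on this carbon. They also leave open what a plain hydrogen there would give, and whether amino acts the same way on another core.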